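Swapping naphthalene for benzodioxin in a cytotoxicity series

A few compounds are considered here, and "the series" means these few. Any claim that something is new, unique, unknown or untested is made for them only; others in the source may bear on it.

Compound 3 `CCOC(=O)CCCCCOc1cccc(CN(C(=O)c2ccc(-c3ccc4ccccc4c3)cc2)C(C)C)c1` belongs to a small set of amides tested for harm to human kidney-derived cells in an ADME assay on HEK293 cells (Homo sapiens) for cytotoxicity, read by CellTiter-Glo and resazurin assay, with a stated time of 72 h; a lower number here means that less compound is needed, a higher number that more compound is needed for the effect. In this assay compound 3 gives > 26000 nM, which is a limit of the assay rather than a measured number. Its two companions behave the same way. Compound 1 `CC(C)COc1cccc(-c2ccc(C(=O)N(Cc3cccc(OCCCCCC(=O)O)c3)C(C)C)cc2)c1` gives > 26000 nM in this assay, again a limit. Compound 2 `COc1cc(F)cc(-c2ccc(C(=O)N(Cc3cccc(OCCCCCC(=O)O)c3)C(C)C)cc2)c1` gives > 26000 nM in this assay, also a limit. Going by the values given here, all three values therefore sit at the limit of > 26000 nM in this assay, at which 3 of the 3 values shown sit, and the only single-point change among them, a step that the two limits leave unreadable from compound 1 to compound 2, cannot be read in size because both ends are limits.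

Compound 4 `CCOC(=O)CCCCCOc1cccc(CN(C(=O)c2ccc(-c3ccc4c(c3)OCCO4)cc2)C(C)C)c1` is the next member. Compared with compound 3 it carries 2,3-dihydro-1,4-benzodioxin-6-yl in place of naphthalen-2-yl on an aromatic carbon. Among the compounds with values here, no measured step in this assay bears directly on such a change, and the one step recorded, from compound 1 to compound 2, is unreadable, so there is no basis for expecting movement beyond the scatter in this assay. The expectation for compound 4 is therefore that it again shows no measurable cell toxicity, an estimated 40000 nM (range 20000 nM to 120000 nM) in this assay. The step that the limit leaves unreadable from compound 3 to compound 4 is expected to be essentially nil, most likely reported once more as a limit.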

Compound 4, half-maximal effective concentration: > 24400 nM
Compound 4 ended at the assay's limit; the forecaster's own chance of this, stated with the estimate: 85%; the middle value lies beyond the limit too.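

Going by these compounds alone, compound 3 and compound 4 both end at limits in this assay, so the swap of naphthalen-2-yl for 2,3-dihydro-1,4-benzodioxin-6-yl gives no step that can be read. The compounds shown leave open at what concentration, if any, each one would harm these cells, and whether any change of group would shift it.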